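Swapping chloro for fluoro in a small cytotoxic set

The compounds below may be only part of what the source reports. "The series", "measured", "known", "first", "only" and "open" are said of these compounds alone.

Of the compounds shown here, three built on a shared core have been tested in a functional assay on cells (Tumor Cell line, Homo sapiens) for cytotoxicity; on this read-out lower numbers stand for stronger inhibition of growth and higher numbers for weaker inhibition of growth. Compound 1 (`Cc1cc(C)c2c(O)cc(-c3ccc(Cl)cc3)nc2n1`) gives 19500 nM, and compound 2 (`Oc1cc(-c2ccc(Cl)cc2)nc2ncccc12`) gives 38900 nM. Compound 3 (`Cc1cnc2nc(-c3ccc(Cl)cc3)cc(O)c2c1`) gives 3720 nM, the lowest of the three numbers and therefore the strongest inhibition of growth in this small set.

Compound 4 (`Cc1cnc2nc(-c3ccc(F)cc3)cc(O)c2c1`) has not yet been measured. It differs from compound 3 in a single place, with fluoro in place of chloro on an aromatic carbon of a six-membered aromatic ring of carbon only, para to a large group (fluoro in place of chloro on an aromatic carbon).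

Among the measured compounds shown here, no measured pair exchanges chloro for fluoro, which leaves the data without a direct guide. For the measured compounds named here, the only measured single-place step is a 10-fold lower number from compound 2 to compound 3 (1.02 log units; beyond the scatter), and it is large. That step is methyl in place of hydrogen, a different change, and it gives no direction here. It does show that one small change can move the number a long way in this set, which argues for a wide range. No step beyond the scatter is expected in this assay, and the expected step is a 1.2-fold higher number from compound 3 to compound 4 (0.08 log units; within the scatter). For compound 4 the estimated value is 4500 nM, with an expected range from 1500 nM to 13000 nM.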

Compound 4, concentration for 50% growth inhibition: 26300 nM
Compound 4: the middle estimate sits 5.8-fold (0.77 log units) below what was measured; measured number outside the range, above it.
By their numbers in this assay, from the lowest: compound 3; then compounds 1, 4 and 2 (each within the scatter of the next).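

In this assay, fluoro in place of chloro gives a 7.1-fold higher number from compound 3 to compound 4 (0.85 log units; beyond the scatter), so this place on the six-membered aromatic ring of carbon only, para to a large group, is sensitive: here chloro goes with stronger inhibition of growth than fluoro. Before this, the only readable step was methyl in place of hydrogen, a 10-fold lower number from compound 2 to compound 3 (1.02 log units; beyond the scatter), at a different place on the shared core, so the number can now be seen to respond at a second place as well. The change is small on paper, with one heavy atom leaving and one entering and no hydrogen-bond donors or acceptors on either group, yet no measurement at hand explains why the number moves.

The compounds shown leave open how bromo, methoxy or an amine would behave at this place, and so whether chloro is close to the best group here or simply better than fluoro. They also leave open whether the same exchange would move the number by a similar amount on the cores of compound 1 and compound 2.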